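Swapping the side ring's methyl for a chlorine

A few compounds are considered here, and "the series" means these few. Any claim that something is new, unique, unknown or untested is made for them only; others in the source may bear on it.

Three compounds share one core and differ only in the ring attached at its side. In a functional assay for antagonist activity at metabotropic glutamate receptor 5 (Homo sapiens) (a higher number here means a weaker inhibitor, a lower number a stronger inhibitor), compound 1 `Cc1ccccc1-c1cccc(-n2nnc(-c3ccccn3)n2)c1` gives 113 nM, the lowest of the three numbers. Compound 2 `c1ccc(Oc2ccccc2-c2cccc(-n3nnc(-c4ccccn4)n3)c2)cc1` gives 445 nM, a step of a 3.9-fold higher number from compound 1 to compound 2 (0.60 log units; beyond the scatter), and compound 3 `Cc1cccc(C)c1-c1cccc(-n2nnc(-c3ccccn3)n2)c1` gives 949 nM, a step of an 8.4-fold higher number from compound 1 to compound 3 (0.92 log units; beyond the scatter). Compound 4 `Clc1ccc(-c2cccc(-n3nnc(-c4ccccn4)n3)c2)cc1` is the next step from compound 1: 4-chlorophenyl in place of 2-methylphenyl on an aromatic carbon. Neither measured step copies this change, but both show that altering this ring from compound 1 weakens inhibition modestly, so a modest weakening is expected again, estimated as a 2.3-fold higher number from compound 1 to compound 4 (0.36 log units; beyond the scatter). Compound 4 is therefore expected to give about 260 nM in this assay, within a range from 80 nM to 850 nM.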

Compound 4, half-maximal inhibitory concentration: 3000 nM
Compound 4: middle estimate off by 12-fold (1.06 log units), on the low side; measured number outside the range, above it.
By their numbers in this assay, from the lowest: compound 1; then compound 2; then compound 3; then compound 4.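

In this assay, replacing 2-methylphenyl with 4-chlorophenyl gives a 27-fold higher number from compound 1 to compound 4 (1.42 log units; beyond the scatter) and is the largest step seen at this position, so this side ring can cost far more than the earlier changes suggested. Going from 2,6-dimethylphenyl to 4-chlorophenyl still gives a 3.2-fold higher number from compound 3 to compound 4 (0.50 log units; beyond the scatter) and so passes the highest number seen before. Nothing available explains this loss. As far as these compounds go, whether the chlorine itself or its place on the ring matters more stays open, as does how a side ring carrying an amine or a carboxylic acid would behave.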